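The source may hold more compounds than are shown below. What is called first, only, known or untested is meant among the compounds shown, and "the series" means these compounds.

In a functional assay on L1210 cells (Mus musculus) for antiproliferative activity, read by cell counting, with a stated time of 2 days (on this read-out higher numbers stand for weaker inhibition and lower numbers for stronger inhibition), compound 1 `COc1cc(C(=O)c2sc(Nc3ccccc3)nc2N)cc(OC)c1OC` gives 18 nM, and compound 3 `COc1ccc(Nc2nc(N)c(C(=O)c3ccc(OC)c(OC)c3)s2)cc1` gives 38 nM. Compound 2 `COc1ccc(C(=O)c2sc(Nc3ccccc3)nc2N)cc1OC` reads > 10000 nM, which is a limit of the assay and not a number; this is the limit of > 10000 nM in this assay, at which 1 of the 3 values shown sits. Compound 4 `COc1cccc(C(=O)c2sc(Nc3ccccc3)nc2N)c1` has not yet been measured. It differs from compound 2 by one change, hydrogen in place of methoxy on an aromatic carbon, ortho to a methoxy group and para to a large group. The same exchange on the same ring gave an at least 550-fold higher number from compound 1 to compound 2 (2.74 log units; beyond the scatter), a large loss. The reverse exchange on a different ring gave an at least 260-fold lower number from compound 2 to compound 3 (2.42 log units; beyond the scatter), a large gain, but it does not touch the place that changes here. The loss seen with compound 2 at > 10000 nM gives no reason to expect recovery, so compound 4 is expected to stay weak, and the assay will probably report only a limit. The expected change is a number no higher from compound 2 to compound 4 (the limit leaves the size open), which would lie within the scatter. For compound 4 the estimated value is 10000 nM, with an expected range from 3000 nM to 30000 nM.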

Compound 4, half-maximal inhibitory concentration: 7600 nM
The estimate for compound 4 lay 1.3-fold (0.12 log units) above the measured number, and the stated range covers the measured number.
By their numbers in this assay, from the lowest: compound 1; then compound 3; then compound 4. At a limit, above all of these: compound 2.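

Compound 2 sits at a limit of the assay, which is not a number: the limit of > 10000 nM in this assay, at which 1 of the 4 values shown sits. In this assay, compound 4 gives this part of the series a measured number, and taking away a methoxy group ortho to a methoxy group and para to a large group gives an at least 1.3-fold lower number from compound 2 to compound 4 (0.11 log units; that floor lies within the scatter), so the true size of the step remains unread. Among these compounds, the same exchange on the same ring gave an at least 550-fold higher number from compound 1 to compound 2 (2.74 log units; beyond the scatter), whereas here it shows only that a compound lacking both of these methoxy groups can still be read as a number.

The compounds shown leave open how far compound 4 truly lies from compound 2. They also do not show whether another group at this position, such as an amine or a hydroxyl, would differ from methoxy or hydrogen.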